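Sulfonyl to sulfanyl exchange in compound 4

The source may report more compounds than this note shows. Statements on the series, on what has been measured and on what is new or still open speak of the compounds shown alone.

Measured so far:
compound 1 `COc1ccccc1/C=C(/SCc1ccc(C)cc1)C(=O)c1ccc(Cl)cc1` gives 10000 nM
compound 2 `O=C(/C(=C\c1ccccc1OCc1ccccc1)S(=O)(=O)c1ccc(Br)cc1)c1ccc(Cl)cc1` gives 1000 nM
compound 3 `Cc1ccc(CS(=O)(=O)/C(=C/c2ccccc2OCc2ccccc2)C(=O)c2ccc(Cl)cc2)cc1` gives 1000 nM

In a functional assay on DU-145 cells (Homo sapiens) for inhibition, read by trypan blue exclusion, with a stated time of 96 h (on this read-out lower numbers stand for stronger inhibition of growth and higher numbers for weaker inhibition of growth), compound 3 stands level with compound 2, the two together giving the lowest numbers of the three, while compound 1 gives 10000 nM. Among the measured compounds shown here, the only single-point step measured, no change at the digits printed from compound 2 to compound 3 (within the scatter), changes nothing within the scatter. Compound 4 `Cc1ccc(CS/C(=C/c2ccccc2OCc2ccccc2)C(=O)c2ccc(Cl)cc2)cc1` differs from compound 3 by (4-methylbenzyl)sulfanyl in place of (4-methylbenzyl)sulfonyl on a double-bonded chain carbon bound to a carbonyl carbon and a double-bonded chain carbon. For the measured compounds named here, no measured pair isolates this change: compound 1 is the only sulfanyl compound, but it also differs from compound 3 at the ether, so its value can only hint. On that hint a higher number is expected for compound 4, the step being a 4.0-fold higher number from compound 3 to compound 4 (0.60 log units; beyond the scatter). The estimate for compound 4 is 4000 nM, with a range from 1200 nM to 15000 nM.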

Compound 4, concentration for 50% growth inhibition: 1000 nM
The estimate for compound 4 lay 4.0-fold (0.60 log units) above the measured number; the measured number lies below the stated range.
By their numbers in this assay, from the lowest: compounds 2, 3 and 4 (each within the scatter of the next); then compound 1.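

In this assay, (4-methylbenzyl)sulfanyl in place of (4-methylbenzyl)sulfonyl gives no change at the digits printed from compound 3 to compound 4 (within the scatter) and (4-methylbenzyl)sulfanyl in place of (4-bromophenyl)sulfonyl gives no change at the digits printed from compound 2 to compound 4 (within the scatter) so all three groups shown at this place read alike. Phenyl in place of hydrogen on the saturated chain carbon bound to an oxygen on an aromatic ring gives a 10-fold lower number from compound 1 to compound 4 (1.00 log units; beyond the scatter) with the (4-methylbenzyl)sulfanyl group held constant, a change the earlier compounds did not isolate. No measured evidence accounts for either result. Still open, as far as these compounds go, is how an amine or a carboxylic acid would read in place of the (4-methylbenzyl)sulfanyl group on this double-bonded chain carbon.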